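A few compounds are considered here, and "the series" means these few. Any claim that something is new, unique, unknown or untested is made for them only; others in the source may bear on it.

Values measured in a functional assay on MGC-803 cells (Homo sapiens) for inhibition, read by MTT assay, with a stated time of 72 h; a higher number here means a weaker inhibitor, a lower number a stronger inhibitor:
- Compound 1 `Cc1cc(N2CC[C@@H](C)[C@@H](N(C)c3ncnc4[nH]ccc34)C2)n2nc(SCc3ccccc3)nc2n1`: 5870 nM
- Compound 2 `Cc1cc(N2CC[C@@H](C)[C@@H](N(C)c3ncnc4[nH]ccc34)C2)n2ncnc2n1`: 4350 nM
- Compound 3 `Cc1cc(N2CC[C@@H](C)[C@@H](N(C)c3ncnc4[nH]ccc34)C2)n2nc(SCc3csc4ccc(Cl)cc34)nc2n1`: > 100000 nM (a limit of the assay, not a number)

Among the measured compounds shown here, only one other compound gives a true number beside compound 1, and the step to it is a 1.3-fold lower number from compound 1 to compound 2 (0.13 log units; within the scatter). Compound 4 `Cc1cc(N2CC[C@@H](C)[C@@H](N(C)c3ncnc4[nH]ccc34)C2)n2nc(SCCc3ccccc3)nc2n1` differs from compound 1 in one place: benzyl in place of phenyl on a saturated chain carbon bound to a sulfur. Put another way, benzylsulfanyl becomes phenethylsulfanyl.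

For the measured compounds named here, two measured steps bear on this. Removing the whole benzylsulfanyl group gave only a 1.3-fold lower number from compound 1 to compound 2 (0.13 log units; within the scatter), whereas changing the same phenyl gave an at least 17-fold higher number from compound 1 to compound 3 (1.23 log units; beyond the scatter). The second step is large, but its replacement group is far bigger than the change in compound 4, so no shift beyond the scatter is expected, though a higher number remains possible. The expected step is a 1.0-fold higher number from compound 1 to compound 4 (0.01 log units; within the scatter). Compound 4 is estimated at 6000 nM, with an expected range of 2500 nM to 20000 nM.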

Compound 4, half-maximal inhibitory concentration: 6190 nM
Beside the measured number, compound 4's estimate is 1.0-fold (0.01 log units) below it; the range from low to high includes it.
By their numbers in this assay, from the lowest: compounds 2, 1 and 4 (each within the scatter of the next). At a limit, above all of these: compound 3.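

Going from benzylsulfanyl to phenethylsulfanyl leaves the reading in this assay unmoved, with a 1.1-fold higher number from compound 1 to compound 4 (0.02 log units; within the scatter), and phenethylsulfanyl compares with hydrogen much as benzylsulfanyl does, with a 1.4-fold higher number from compound 2 to compound 4 (0.15 log units; within the scatter). Among these compounds, a plain phenyl ring on either chain length therefore makes no measurable difference at this position. Compound 3, whose value is a limit and not a number, stands apart, with an at least 16-fold lower number from compound 3 to compound 4 (1.20 log units; beyond the scatter).

Still open, going by these compounds, is whether an amine or a carboxylic acid on the phenyl ring, or a longer chain, would shift the number. Also open, on these data alone, is whether the change in compound 3 comes from the chlorine or from the rest of 5-chloro-1-benzothiophen-3-yl.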